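Removing the benzyl from the aromatic oxygen: compound 3

The source may hold more compounds than are shown below. What is called first, only, known or untested is meant among the compounds shown, and "the series" means these compounds.

Among the compounds with values here, compound 2 `CCCCCCCCN(C)C(=O)Cn1cc(Cc2cnc(OCc3ccccc3)nc2)c(=O)nc1SCc1ccc(F)cc1` carries a benzyloxy group and is the lower of the two measured members: in a functional assay on a cell-free system (plasma) for inhibition of platelet-activating factor acetylhydrolase (Homo sapiens), tested at 100 nM (a higher number here means more inhibition at the concentration tested (going by the name of the read-out), a lower number less inhibition), compound 2 gives 10%. Its nearest neighbour is compound 1 `CCCCCCCCN(C)C(=O)Cn1cc(Cc2cnc(OC)nc2)c(=O)nc1SCc1ccc(F)cc1`, the methoxy analogue, which in this assay gives 39%. Within the data shown here, the one measured step, a number 29 percentage points lower from compound 1 to compound 2 (beyond the scatter), is the only direct information on what the aromatic oxygen substituent does to inhibition.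

Compound 3 `CCCCCCCCN(C)C(=O)Cn1cc(Cc2cnc(O)nc2)c(=O)nc1SCc1ccc(F)cc1` is the unsubstituted hydroxy analogue. The change from compound 2 is hydrogen in place of benzyl on an oxygen on an aromatic ring. Among the measured compounds shown here, this undoes the phenyl addition of the measured step and goes one carbon further, to hydrogen; no measured pair covers the last part, methoxy against hydroxy. The step of a number 29 percentage points lower from compound 1 to compound 2 (beyond the scatter) therefore bears on it in reverse: loss of the benzyl is expected to restore inhibition toward the level of compound 1, and a rise of a number 25 percentage points higher from compound 2 to compound 3 (beyond the scatter) is estimated, with the hydroxy-specific part unknown. Compound 3 is thus expected to give about 35%, within 15% to 55%.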

Compound 3, a percentage reported as inhibition, at one concentration (the size of the read-out at that concentration, not a potency): 66%
For compound 3 the middle estimate is 31 percentage points below the measured one; the measured number lies above the stated range.
By their numbers in this assay, from the lowest: compound 2; then compound 1; then compound 3.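

In this assay the hydroxy group gives the highest number of the three compounds, with a number 56 percentage points higher from compound 2 to compound 3 (beyond the scatter) on loss of the benzyl and a number 27 percentage points higher from compound 1 to compound 3 (beyond the scatter) on loss of the methyl alone. The methoxy of compound 1 therefore does not mark the top of this position. Inhibition rises from benzyl through methyl to hydrogen on the oxygen, and this order holds for all three compounds, with none going against it, though three points are a narrow base for a trend. No measurement at hand accounts for this order.

On these data alone, whether the gain depends on the hydroxy group itself or only on the absence of a carbon group on the oxygen stays open, and an amine or a carboxylic acid in the same place would be needed to separate the two. These numbers are also the size of the read-out at one concentration and not potencies, so compound 3 can be said to have a stronger effect than compound 1 at that concentration only.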